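Methoxy for iodo on the shared core: tolerance estimate

A few compounds are considered here, and "the series" means these few. Any claim that something is new, unique, unknown or untested is made for them only; others in the source may bear on it.

Two compounds of the series have been run in an ADME assay on RAW264.7 cells (Mus musculus) for cytotoxicity, read by MTT assay, with a stated time of 18 h; a lower number here means that less compound is tolerated, a higher number that more compound is tolerated. Compound 1 `C=C1C(=O)OC[C@@H]1CCOC(=O)Nc1ccc(I)cc1` gives 12500 nM. Compound 2 `C=C1C(=O)OC[C@@H]1CCOC(=O)Nc1cc(C(F)(F)F)cc(C(F)(F)F)c1` carries two trifluoromethyl groups on the aromatic ring in place of the iodo of compound 1; in this assay compound 2 gives 12400 nM. Among the compounds with values here, of the two numbers, compound 1 is the one at the upper end, but the gap to compound 2 lies within the scatter, so the two measured compounds cannot be told apart in this assay; no step between them is counted, and the two aromatic substitutions differ in more than one place.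

Compound 3 `C=C1C(=O)OC[C@@H]1CCOC(=O)Nc1ccc(OC)cc1` is the next compound to be measured in this assay. Relative to compound 1 it shows (methoxy in place of iodo on an aromatic carbon). With the two measured compounds sitting together despite their different aromatic substitution, no step beyond the scatter is expected from compound 1 to compound 3 in this assay; the estimated step is a 1.0-fold higher number from compound 1 to compound 3 (0.02 log units; within the scatter). Compound 3 is therefore expected to give about 13000 nM, within a range from 6000 nM to 28000 nM.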

Compound 3, half-maximal cytotoxic concentration: 11900 nM
Beside the measured number, compound 3's estimate is 1.1-fold (0.04 log units) above it; the range from low to high includes it.
By their numbers in this assay, from the lowest: compounds 3, 2 and 1 (each within the scatter of the next).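

In this assay, within the data shown here, exchanging iodo for methoxy on an aromatic carbon, para to a large group, gives a 1.1-fold lower number from compound 1 to compound 3 (0.02 log units; within the scatter), and this is the first step that can be read at a single place. At this position, then, a halogen and an oxygen-linked group give numbers that cannot be told apart, even though the entering methoxy brings a hydrogen-bond acceptor that the leaving iodo lacks and has one more heavy atom. No measurement available for these compounds bears on why the number holds across this change.

Among these compounds, this is one exchange at one place, so it sets no general rule for the position, and compound 2 differs from compound 3 in more than one place and adds no step to the comparison. Still open, as far as these compounds go, is whether an amine, a carboxylic acid or a longer alkoxy chain at this same aromatic carbon would move the number in this assay beyond the scatter, and what the unsubstituted aromatic ring would give on the shared core.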